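The source may hold more compounds than are shown below. What is called first, only, known or untested is meant among the compounds shown, and "the series" means these compounds.

Compound 1 `Cc1nc(C)c(/C=C/C(=O)/C=C/c2cccc(O)c2)nc1C`: 3700 nM
Compound 2 `COc1ccc(/C=C/C(=O)/C=C/c2nc(C)c(C)nc2C)cc1OC`: 2440 nM
Compound 3 `COc1ccc(/C=C/C(=O)/C=C/c2nc(C)c(C)nc2C)c(OC)c1`: 2850 nM

In a functional assay on A549/CDDP cells (Homo sapiens) for antiproliferative activity, read by MTT assay, with a stated time of 72 h (a lower number here means a stronger inhibitor, a higher number a weaker inhibitor), compound 1 stands level with compound 2 and compound 3, since all three values lie within the usual scatter of repeated measurements. Compound 4 `Cc1nc(C)c(/C=C/C(=O)/C=C/c2ccc(Cl)cc2)nc1C`, not yet measured, carries 4-chlorophenyl in place of 3-hydroxyphenyl on a double-bonded chain carbon bound to a double-bonded chain carbon. Among the measured compounds shown here, no measured pair differs in just one place, so the data give no direct guide to this change. Compound 2 at 2440 nM and compound 3 at 2850 nM stay close to compound 1 at 3700 nM, so no step beyond the scatter is expected. The estimated step is a 1.5-fold lower number from compound 1 to compound 4 (0.17 log units; within the scatter). For compound 4, the expected value is 2500 nM, with an estimated range of 900 nM to 7000 nM.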

Compound 4, half-maximal inhibitory concentration: 7490 nM
Estimate against measurement, compound 4: 3.0-fold (0.48 log units) below, and the stated range ends below it.
By their numbers in this assay, from the lowest: compounds 2, 3 and 1 (each within the scatter of the next); then compound 4.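

Among the compounds shown here, this is the first single change that can be read in this assay: 4-chlorophenyl in place of 3-hydroxyphenyl gives a 2.0-fold higher number from compound 1 to compound 4 (0.31 log units; beyond the scatter) and so a modestly weaker compound. The position on a double-bonded chain carbon bound to a double-bonded chain carbon therefore responds to the group it carries. No measurement shown here explains this loss. The swap changes both the substituent and its place on the phenyl ring, so these two effects cannot be separated. On these data alone, how an amine or a carboxylic acid on that ring would fare remains open.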